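This account rests on a few compounds, and the source may have more. Where it says the series, first, only, none or still open, it means among the compounds named here.

For the measured compounds named here, in a functional assay on cells (Panel renal (Carcinoma cell lines), Homo sapiens) for inhibition, read by sulforhodamine B assay, with a stated time of 48 h (on this read-out higher numbers stand for weaker inhibition of growth and lower numbers for stronger inhibition of growth), compound 1 (`CN1CCN(CCCOc2cccc3nc(Nc4ccc(Cl)c(C(F)(F)F)c4)ccc23)CC1`) gives 3230 nM while compound 2 (`CN1CCN(CCCOc2cccc3nc(Nc4ccc(F)c(F)c4)ccc23)CC1`) gives 8980 nM as the higher of the only two numbers available. Going by the values given here, one measured step bears on what follows: a 2.8-fold higher number from compound 1 to compound 2 (0.44 log units; beyond the scatter) is modest and arises at the same place as the next change. For compound 3 (`CN1CCN(CCCOc2cccc3nc(Nc4cccc(Cl)c4)ccc23)CC1`) the difference 3-chlorophenyl in place of 3,4-difluorophenyl on a nitrogen on an aromatic ring means 3-chlorophenyl in place of 3,4-difluorophenyl on a nitrogen on an aromatic ring. Among the compounds with values here, the only other chloro-bearing group measured is the one in compound 1 at 3230 nM on the lower side, so a small move towards a lower number is expected, smaller than the measured step. The expected change is a 1.5-fold lower number from compound 2 to compound 3 (0.18 log units; within the scatter) and no more than that. Compound 3 is estimated at 6000 nM with 2800 nM to 13000 nM as the expected range.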

Compound 3, concentration for total growth inhibition: 5370 nM
Beside the measured number, compound 3's estimate is 1.1-fold (0.05 log units) above it; the measured number falls inside the stated range.
By their numbers in this assay, from the lowest: compounds 1, 3 and 2 (each within the scatter of the next, the first and the last beyond it).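

In this assay, 3-chlorophenyl on a nitrogen on an aromatic ring cannot be told apart from either earlier group: the change from 3,4-difluorophenyl gives a 1.7-fold lower number from compound 2 to compound 3 (0.22 log units; within the scatter), and the change from 4-chloro-3-(trifluoromethyl)phenyl gives a 1.7-fold higher number from compound 1 to compound 3 (0.22 log units; within the scatter). For the compounds shown here, the only step at this position beyond the scatter therefore remains a 2.8-fold higher number from compound 1 to compound 2 (0.44 log units; beyond the scatter), and the third group does not divide that gap into two separable steps. Nothing given here explains these numbers.

The compounds shown leave open whether an unsubstituted phenyl, a 4-methoxyphenyl or a pyridyl group at this place would give a number within the scatter of these three or one clearly apart from them. On these data alone, how the same steps would read outside this assay also remains open.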